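Hydroxymethyl to carboxy step across two related cores

This account rests on a few compounds, and the source may have more. Where it says the series, first, only, none or still open, it means among the compounds named here.

Measured so far:
Compound 1 `OC[C@H]1C[C@@H](Cl)C[C@@H](c2ccc3ccccc3c2)O1`: in a functional assay on the whole organism (Abdomen, strain Swiss albino) for inhibition, with Mus musculus as the target, in the writhing test, with a stated time of 30 min, at a dose of 30 mg/kg by the oral route (on this read-out lower numbers stand for less inhibition and higher numbers for more inhibition at the one dose given (going by the name of the read-out)), compound 1 gives 46.6%
Compound 2 `OC[C@H]1C[C@@H](Cl)C[C@@H](c2cccc3ccccc23)O1`: in this assay compound 2 gives 87.5%
Compound 3 `O=C(O)[C@H]1C[C@@H](Cl)C[C@@H](c2ccc3ccccc3c2)O1`: in this assay compound 3 gives 28.1%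

Compound 2 stands highest of the three, and its steps to compound 1 and to compound 3 both lie beyond the scatter. Compound 1 and compound 2 are built from the same atoms joined differently; the difference between the two cores is not broken down here.

On the core of compound 1 one change has been measured: carboxy in place of hydroxymethyl on a saturated ring carbon. It gave a number 18.5 percentage points lower from compound 1 to compound 3 (beyond the scatter), a modest loss of inhibition in this assay.

Compound 4 `O=C(O)[C@H]1C[C@@H](Cl)C[C@@H](c2cccc3ccccc23)O1` has not been measured. Within the data shown here, it differs from compound 2 by carboxy in place of hydroxymethyl on a saturated ring carbon, the same change at the same place, so the step from compound 1 to compound 3 is the only guide. The change is seen twice in all among these compounds. Among the measured compounds shown here, because compound 2 starts from 87.5%, a higher point than compound 1, the drop could be somewhat larger in percentage points than a number 18.5 percentage points lower from compound 1 to compound 3 (beyond the scatter), but there is no second measured pair to check this.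

In this assay compound 4 is expected to show a number 25.5 percentage points lower from compound 2 to compound 4 (beyond the scatter). The estimate for compound 4 is 62%, with a range from 40% to 82%.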

Compound 4, a percentage reported as inhibition, in the whole organism at one dose (the size of the read-out at that dose, not a potency): 54.4%
Estimate against measurement, compound 4: 7.6 percentage points above; the range from low to high includes it.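

In this assay, carboxy in place of hydroxymethyl on a saturated ring carbon lowers the read-out on the second core as well, giving a number 33.1 percentage points lower from compound 2 to compound 4 (beyond the scatter), so the direction of the change is the same on both cores. The size of the step does not carry over unchanged from one core to the other: the same change on two cores in this assay, a number 18.5 percentage points lower (beyond the scatter) from compound 1 to compound 3 and a number 33.1 percentage points lower (beyond the scatter) from compound 2 to compound 4, 14.6 percentage points apart, beyond the scatter of two such steps. These two pairs do not show whether the larger step goes with the higher starting value of compound 2 or with the core itself, and they give no basis for predicting the size of the step on any further core; each value also comes from a single dose, so neither step is a change in potency.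

The compounds shown carry only hydroxymethyl or carboxy at this ring carbon, which leaves open how a primary amide, a methyl ester, an aminomethyl group or a longer chain such as hydroxyethyl would behave there. Also open, on these data alone, is whether the step keeps its direction when a fluoro or hydroxy group replaces the chloro group on its ring atom.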